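Branching the butyl chain of compound 3

The source may hold more compounds than are shown below. What is called first, only, known or untested is meant among the compounds shown, and "the series" means these compounds.

In a functional assay on PC-3 cells (Homo sapiens) for inhibition, read by sulforhodamine B assay, with a stated time of 72 h (on this read-out lower numbers stand for stronger inhibition and higher numbers for weaker inhibition), compound 1 (`CC1CCN(C(=O)c2c(N)sc(-c3ccc(Cl)cc3)c2-c2ccc(Cl)cc2)CC1`) gives 5750 nM, and compound 3 (`CCCCNC(=O)c1c(N)sc(-c2ccc(Cl)cc2)c1-c1ccc(Cl)cc1`) gives 17800 nM. Compound 2 (`Nc1sc(-c2ccc(Cl)cc2)c(-c2ccc(Cl)cc2)c1C(=O)Nc1ccccc1`) reads > 50000 nM, which is a limit of the assay and not a number. Compound 3 therefore holds the higher of the two true numbers, and compound 1 is its nearest neighbour, at a 3.1-fold higher number from compound 1 to compound 3 (0.49 log units; beyond the scatter).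

Compound 4 (`CC(C)CNC(=O)c1c(N)sc(-c2ccc(Cl)cc2)c1-c1ccc(Cl)cc1`) has the same atoms as compound 3, joined differently: isopropyl in place of propyl on a saturated chain carbon bound to an amide-type nitrogen. Butyl thus becomes isobutyl.

Among the compounds with values here, two measured steps bear on this change, a 3.1-fold higher number from compound 1 to compound 3 (0.49 log units; beyond the scatter) and an at least 2.8-fold lower number from compound 2 to compound 3 (0.44 log units; beyond the scatter). Both replace the whole group on the carbonyl or the amide-type nitrogen, a larger change than this one, and neither tests branching alone. The estimated step is a 1.2-fold lower number from compound 3 to compound 4 (0.07 log units; within the scatter), so none beyond the scatter is expected in this assay. Compound 4 is expected at about 15000 nM, with an estimated range of 8000 nM to 32000 nM.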

Compound 4, half-maximal inhibitory concentration: 13200 nM
Estimate against measurement, compound 4: 1.1-fold (0.06 log units) above; measured number inside the range.
By their numbers in this assay, from the lowest: compound 1; then compounds 4 and 3 (each within the scatter of the next). At a limit, above all of these: compound 2.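

In this assay, within the data shown here, the change from butyl to isobutyl on the amide-type nitrogen gives a 1.3-fold lower number from compound 3 to compound 4 (0.13 log units; within the scatter) and is the first change here to test branching alone, with the same atoms joined differently, leaving the read-out within the scatter. The branched chain keeps the separation from the other amides, with a 2.3-fold higher number from compound 1 to compound 4 (0.36 log units; beyond the scatter) on the side of the 4-methylpiperidin-1-yl amide and an at least 3.7-fold lower number from compound 2 to compound 4 (0.57 log units; beyond the scatter) on the side of the anilino amide. The value of compound 2 is a limit of the assay and not a number: the limit of > 50000 nM in this assay, at which 1 of the 4 values shown sits.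

The compounds shown leave open whether a tert-butyl group, an unsubstituted piperidine or a morpholine on this carbonyl would read with compound 3 and compound 4 or with compound 1. They also give no cause for any of these steps.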